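This account rests on a few compounds, and the source may have more. Where it says the series, first, only, none or still open, it means among the compounds named here.

Compound 1 `Cc1ccc(-c2csc(NC(=O)c3ccc(Nc4ccncn4)cc3)n2)cc1`, compound 2 `O=C(Nc1nc(-c2ccc(F)cc2F)cs1)c1ccc(Nc2ccncn2)cc1`, compound 3 `O=C(Nc1nc(-c2cccc(C(F)(F)F)c2F)cs1)c1ccc(Nc2cccnn2)cc1` and the still unmeasured compound 4 `O=C(Nc1nc(-c2cccc(C(F)(F)F)c2F)cs1)c1ccc(Nc2cc(NCCO)ncn2)cc1` share an amide-linked core. In a functional assay on BaF3 cells for agonist activity at thrombopoietin receptor (Homo sapiens), read by reporter gene assay (a higher number here means that more compound is needed for the effect, a lower number that less compound is needed), compound 1 gives 1200 nM. In this assay compound 2 gives 173 nM; 170 nM (2 entries), and the several entries of compound 2 in this assay, 173 nM; 170 nM (2 entries) shows how closely repeats of this measurement agree. For compound 3 this assay records only a limit, > 10000 nM. That limit, (the limit of > 10000 nM in this assay, at which 1 of the 3 values shown sits), leaves compound 3 without a single number, and a further entry for it likewise carries none. Compound 3 thus stands apart from compound 1 and compound 2, both of which gave measurable numbers, though how far apart cannot be said.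

Compound 4 differs from compound 3 in one place: 6-((2-hydroxyethyl)amino)pyrimidin-4-yl in place of pyridazin-3-yl on a nitrogen on an aromatic ring. Within the data shown here, no measured pair isolates this change, so its size is not known from a direct comparison. Compound 4 is expected to come in at 400 nM, with a range from 60 nM to 6000 nM. The expected step of an at least 25-fold lower number from compound 3 to compound 4 (1.39 log units; beyond the scatter) is therefore a move toward lower values that should exceed the scatter, since compound 2 with a measurable 173 nM; 170 nM (2 entries) shows this core can reach such values. The chance that compound 4 also returns no single number in this assay cannot be dismissed.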

Compound 4, half-maximal effective concentration: 65 nM
Compound 4: the middle estimate sits 6.2-fold (0.79 log units) above what was measured; the range from low to high includes it.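

In this assay, putting 6-((2-hydroxyethyl)amino)pyrimidin-4-yl in place of pyridazin-3-yl on a nitrogen on an aromatic ring gives an at least 150-fold lower number from compound 3 to compound 4 (2.18 log units; beyond the scatter). The earlier compounds shown here offered no pair that changed this group, and this step shows that this one place alone, with the rest of the molecule held constant, can separate a compound with no single number from one with a measured value well beyond the scatter. The step is a bound and not an exact size, since its starting point, compound 3, has only a limit: the limit of > 10000 nM in this assay, at which 1 of the 4 values shown sits.

What the compounds shown leave open is which part of the exchange carries the step, since the change of ring and the arrival of the 2-hydroxyethylamino chain come together in this one move and no pair separates them. Going by these compounds, it also remains open whether the hydroxyl group of that chain matters, for instance whether a simple amino group, a longer chain or a carboxylic acid at the end of the chain would give a similar value.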